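The source may hold more compounds than are shown below. What is called first, only, known or untested is meant among the compounds shown, and "the series" means these compounds.

Series notes, cytotoxicity. Compound 1 `CCOC(=O)CCCCCOc1cccc(CN(C(=O)c2ccc(-c3cc(F)cc(OC)c3)cc2)C(C)C)c1` and compound 2 `CCOC(=O)CCCCCOc1cccc(CN(C(=O)c2ccc(-c3cccc(Br)c3)cc2)C(C)C)c1` share the core and differ only in the aryl group on the biphenyl. In an ADME assay on HEK293 cells (Homo sapiens) for cytotoxicity, read by CellTiter-Glo and resazurin assay, with a stated time of 72 h (on this read-out lower numbers stand for an effect already at smaller amounts and higher numbers for an effect only at larger amounts of compound), compound 1 gives > 26000 nM, which is a limit of the assay and not a number. In this assay compound 2 likewise gives > 26000 nM, again a limit. The step that the two limits leave unreadable from compound 1 to compound 2 is therefore unreadable; on the numbers shown compound 2 stands at the limit, and both values sit there (the limit of > 26000 nM in this assay, at which 2 of the 2 values shown sit).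

Compound 3 `CCOC(=O)CCCCCOc1cccc(CN(C(=O)c2ccc(-c3cccc(CC(=O)O)c3)cc2)C(C)C)c1` is the next member. Its difference from compound 2 is carboxymethyl in place of bromo on an aromatic carbon, meta to a large group. No measured step bears on this change with a readable size, since the only step shown, from compound 1 to compound 2, was hidden by the two limits. With no readable step to lean on, no shift beyond the scatter is expected from compound 2 to compound 3, and the step that the limit leaves unreadable from compound 2 to compound 3 is estimated accordingly. For compound 3 in this assay the expected value is 40000 nM, within 15000 nM to 110000 nM, most likely reported again as a limit.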

Compound 3, half-maximal effective concentration: > 26000 nM
Compound 3 ended at the assay's limit; the forecaster's own chance of this, stated with the estimate: 85%; the middle value lies beyond the limit too.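

Compound 3 joins compound 1 and compound 2 at a limit of the assay and not at a number, so no step among the three can be read: the limit of > 26000 nM in this assay, at which 3 of the 3 values shown sit.

The compounds shown leave open at what concentration any of the three would reach half-maximal effect, and whether the differing aryl substituent alters it at all.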